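Adding a benzyl group to compound 2

The source may hold more compounds than are shown below. What is called first, only, known or untested is meant among the compounds shown, and "the series" means these compounds.

Measured so far in a functional assay on HL-60 cells (Homo sapiens) for antiproliferative activity, read by MTT assay; a higher number here means a weaker inhibitor, a lower number a stronger inhibitor:
Compound 1 `C#CC[C@@H]1O[C@H](COCc2ccccc2)[C@@H](OCc2ccccc2)[C@H](OCc2ccccc2)[C@H]1O` gives "not active" (no number reported)
Compound 2 `O[C@@H]1[C@@H](OCc2ccccc2)[C@H](O)[C@@H](COCc2ccccc2)O[C@H]1Cc1ccccc1` gives 35300 nM

Among the compounds with values here, compound 2 holds the only number in this small set, as compound 1 was reported without one. Compound 3 `O[C@@H]1[C@@H](OCc2ccccc2)[C@H](OCc2ccccc2)[C@@H](COCc2ccccc2)O[C@H]1Cc1ccccc1` differs from compound 2 by benzyl in place of hydrogen on an oxygen on a saturated carbon (benzyl in place of hydrogen on an oxygen on a saturated carbon, hydroxy to benzyloxy). Within the data shown here, no measured step exists to scale this change, so no step beyond the scatter is expected in this assay for it. The expected shift is a 1.2-fold lower number from compound 2 to compound 3 (0.07 log units; within the scatter) as estimated here. For compound 3 the expected value is 30000 nM within an estimated range of 12000 nM to 75000 nM when measured.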

Compound 3, half-maximal inhibitory concentration: 8700 nM
The estimate for compound 3 lay 3.4-fold (0.54 log units) above the measured number, outside the stated range (below it).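

In this assay, replacing hydrogen with benzyl on this oxygen on a saturated carbon gives a 4.1-fold lower number from compound 2 to compound 3 (0.61 log units; beyond the scatter) and so a step beyond the usual scatter. The free hydroxy of compound 2 is therefore not required for activity here, and the larger benzyloxy group is tolerated. Nothing measured explains this step.

The compounds shown leave open whether the lower number needs the benzyl ring itself or would also follow from a methyl ether or a longer chain ending in an amine on this oxygen. Going by these compounds, the role of the hydroxy that remains on compound 3 also stays open.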